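Swapping the halogen pattern on the benzyl ether group

This account rests on a few compounds, and the source may have more. Where it says the series, first, only, none or still open, it means among the compounds named here.

Three compounds share one core, differing only in the aromatic ring carried by the ether. Compound 1 `N[C@]1(C(=O)O)[C@H]2[C@@H](C[C@H]1OCc1cccc(C(F)(F)F)c1)[C@]2(F)C(=O)O` gives 5.72 nM in an assay on CHO cells for binding affinity to metabotropic glutamate receptor 2 (Rattus norvegicus); a lower number here means a stronger inhibitor, a higher number a weaker inhibitor. Compound 2 `N[C@]1(C(=O)O)[C@H]2[C@@H](C[C@H]1OCc1cccc(Oc3ccccc3)c1)[C@]2(F)C(=O)O` gives 7.15 nM in this assay; the change from compound 1 to compound 2, phenoxy in place of trifluoromethyl on an aromatic carbon, gave a 1.3-fold higher number from compound 1 to compound 2 (0.10 log units; within the scatter). Compound 3 `N[C@]1(C(=O)O)[C@H]2[C@@H](C[C@H]1OCc1cc(F)cc(F)c1)[C@]2(F)C(=O)O` gives 12.4 nM in this assay, the highest of the three numbers: it sits within the scatter of compound 2 but beyond the scatter of compound 1.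

Compound 4 `N[C@]1(C(=O)O)[C@H]2[C@@H](C[C@H]1OCc1ccc(F)c(Cl)c1)[C@]2(F)C(=O)O` has not yet been measured. It differs from compound 3 by 3-chloro-4-fluorophenyl in place of 3,5-difluorophenyl on a saturated chain carbon bound to an oxygen on a saturated carbon. Among the measured compounds shown here, the only measured single step, from compound 1 to compound 2, also exchanges one substituent for another on the aromatic ring and stayed within the scatter; no measured pair exchanges one halogen pattern for another, so the bearing of that step is indirect. On this basis a step of no clear size beyond the scatter is expected, with a 1.4-fold lower number from compound 3 to compound 4 (0.14 log units; within the scatter) as the estimated move. Compound 4 is therefore expected to give about 9 nM in this assay, with a range from 4 nM to 22 nM.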

Compound 4, inhibition constant: 3.57 nM
Estimate against measurement, compound 4: 2.5-fold (0.40 log units) above; the whole stated range lies above it.
By their numbers in this assay, from the lowest: compounds 4, 1, 2 and 3 (each within the scatter of the next, the first and the last beyond it).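

In this assay, 3-chloro-4-fluorophenyl in place of 3,5-difluorophenyl on a saturated chain carbon bound to an oxygen on a saturated carbon gives a 3.5-fold lower number from compound 3 to compound 4 (0.54 log units; beyond the scatter) and so clears the scatter, whereas the earlier change on this ring gave a 1.3-fold higher number from compound 1 to compound 2 (0.10 log units; within the scatter) and did not. The group that leaves and the group that enters have the same count of heavy atoms, the same aromatic ring and no hydrogen-bond donors or acceptors, differing only in one chlorine for one fluorine and in the pattern the halogens form, so this position separates two halogen patterns that match on all those counts. Nothing shown here bears on why the two patterns part in this way.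

From the compounds shown here alone, how a 3-chlorophenyl or a 4-fluorophenyl group alone would read stays open, so the part played by the chlorine cannot be told apart from that of the changed fluorine pattern. Also open, going by these compounds, is whether a bromine in place of the chlorine, a nitrile on the ring or a longer chain carrying the ring would stay near compound 4 at 3.57 nM in this assay or move away from it.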